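The source may report more compounds than this note shows. Statements on the series, on what has been measured and on what is new or still open speak of the compounds shown alone.

Compound 1 `Cc1ccc(S(=O)(=O)NCc2cn(C[C@H](O)[C@H]3OC(=O)C(OCc4ccccc4)=C3OCc3ccccc3)nn2)cc1`: 13100 nM
Compound 2 `COc1ccc(-c2cn(C[C@H](O)[C@H]3OC(=O)C(OCc4ccccc4)=C3OCc3ccccc3)nn2)cc1`: > 100000 nM

In a functional assay on HCT-116 cells (Homo sapiens) for antiproliferative activity, read by MTT assay, with a stated time of 72 h (on this read-out lower numbers stand for stronger inhibition and higher numbers for weaker inhibition), compound 1 gives 13100 nM. For compound 2 this assay reports only a limit, > 100000 nM, which is not a number; compound 2 therefore stands at the weak end of the two values shown, at the limit of > 100000 nM in this assay, at which 1 of the 2 values shown sits. Among the compounds with values here, the single measured step, an at least 7.6-fold higher number from compound 1 to compound 2 (0.88 log units; beyond the scatter), shows that exchanging the group on this carbon of the shared core can shift the number considerably. Compound 3 `O=C1O[C@H]([C@@H](O)Cn2cc(C3CC3)nn2)C(OCc2ccccc2)=C1OCc1ccccc1` is not yet measured; it differs from compound 2 by cyclopropyl in place of 4-methoxyphenyl on an aromatic carbon. Within the data shown here, no measured step involves cyclopropyl, so the step from compound 1 to compound 2 only indicates that this position is sensitive. Compound 2 already stands at a limit. The change expected is an at least 1.6-fold lower number from compound 2 to compound 3 (0.22 log units; that floor lies within the scatter), a modest drop at most. For compound 3 the estimate in this assay is 60000 nM, ranging from 15000 nM to 200000 nM.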

Compound 3, half-maximal inhibitory concentration: 30400 nM
For compound 3 the middle estimate is 2.0-fold (0.30 log units) above the measured one; the measured number falls inside the stated range.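

In this assay, cyclopropyl in place of 4-methoxyphenyl gives an at least 3.2-fold lower number from compound 2 to compound 3 (0.51 log units; beyond the scatter), showing that a much smaller group made only of carbon can bring the number down from the weak end of the series. As far as these compounds go, compound 2 stands at a limit, not a number, so the true size of this step stays unknown: the limit of > 100000 nM in this assay, at which 1 of the 3 values shown sits. Cyclopropyl still falls short of the group in compound 1, with a 2.3-fold higher number from compound 1 to compound 3 (0.37 log units; beyond the scatter), which places (((4-methylphenyl)sulfonyl)amino)methyl ahead of both replacements at this position.

The three groups differ in several ways at once, and the compounds shown cannot separate which feature sets the number. From the compounds shown here alone, whether an amine, a carboxylic acid or a longer alkyl chain on this carbon would reach a lower number than compound 1 remains open.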